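Hydrogen in place of chloro on compound 2

The source may report more compounds than this note shows. Statements on the series, on what has been measured and on what is new or still open speak of the compounds shown alone.

Compound 1 `CC1Cn2cc([N+](=O)[O-])nc2O1`: > 500000 nM, a limit
Compound 2 `CC1Cn2c(nc([N+](=O)[O-])c2-c2ccc(Cl)cc2)O1`: > 250000 nM, a limit
Compound 3 `CC1Cn2c(nc([N+](=O)[O-])c2-c2cccc(C#N)c2)O1`: > 500000 nM, a limit

All three results in an ADME assay on CHO cells (Cricetulus griseus) for cytotoxicity, read by MTT assay, with a stated time of 24 h (a higher number here means that more compound is tolerated, a lower number that less compound is tolerated), are limits and not numbers. Compound 2 stands at the limit of > 250000 nM in this assay, at which 1 of the 3 values shown sits. Compounds 1 and 3 stand at the limit of > 500000 nM in this assay, at which 2 of the 3 values shown sit.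

Compound 4 `CC1Cn2c(nc([N+](=O)[O-])c2-c2ccccc2)O1` has not yet been measured. It has hydrogen in place of chloro on an aromatic carbon of compound 2 (hydrogen in place of chloro on an aromatic carbon). Going by the values given here, no measured pair shows the size of such a change, so no shift beyond the scatter is expected in this assay, in either direction. The expected step that the limit leaves unreadable from compound 2 to compound 4 is small. For compound 4 the estimate is 400000 nM, within an expected range of 200000 nM to 700000 nM.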

Compound 4, half-maximal cytotoxic concentration: > 500000 nM
Compound 4 was reported as a limit; the forecaster's own chance of this, stated with the estimate: 85%; middle value at least 1.2-fold (0.09 log units) away from the limit.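

Going by these compounds alone, all four results in this assay are limits, and no step linking compound 4 with compound 1, compound 2 or compound 3 can be read. The compounds shown leave open where any of them reaches its half-maximal cytotoxic concentration, and whether hydrogen, chloro or cyano makes any difference.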